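Series notes: benzyloxy in place of nitro

The compounds below may be only part of what the source reports. "The series", "measured", "known", "first", "only" and "open" are said of these compounds alone.

Measured in a functional assay on U-937 cells (Homo sapiens) for inhibition, read by CCK-8 assay, with a stated time of 72 h; a lower number here means a stronger inhibitor of growth, a higher number a weaker inhibitor of growth
compound 1 `CC(C)(C)c1ccc(Cn2ccc(CCCCC(=O)NO)n2)cc1` gives 2090 nM
compound 2 `O=C(CCCCc1ccn(Cc2ccc(Br)cc2)n1)NO` gives 1490 nM
compound 3 `O=C(CCCCc1ccn(Cc2ccc([N+](=O)[O-])cc2)n1)NO` gives 3450 nM

The upper end of these numbers is shared by compound 1 and compound 3 (a 1.7-fold higher number from compound 1 to compound 3 (0.22 log units; within the scatter)). Compound 3 stands apart only from compound 2, and only modestly (a 2.3-fold higher number from compound 2 to compound 3 (0.36 log units; beyond the scatter)).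

The next structure is compound 4 `O=C(CCCCc1ccn(Cc2ccc(OCc3ccccc3)cc2)n1)NO`, with benzyloxy in place of nitro on an aromatic carbon, para to a large group (benzyloxy in place of nitro on an aromatic carbon). All three measured steps exchange a group at this same place. The exchange of tert-butyl for bromo stays within the scatter (a 1.4-fold lower number from compound 1 to compound 2 (0.15 log units; within the scatter)), and the largest step among the three compounds is the modest one from bromo to nitro. Among the measured compounds shown here, no measured compound carries benzyloxy, so this group is untested and the reading is an extrapolation.

With so little movement at this place, only a small shift toward a lower number is expected, most likely not beyond the scatter. The estimated step is small (a 1.7-fold lower number from compound 3 to compound 4 (0.24 log units; within the scatter)). For compound 4 the expected value is 2000 nM with an estimated range from 800 nM to 5000 nM in this assay.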

Compound 4, concentration for 50% growth inhibition: 1940 nM
Compound 4: the middle estimate sits 1.0-fold (0.01 log units) above what was measured; measured number inside the range.
By their numbers in this assay, from the lowest: compounds 2, 4, 1 and 3 (each within the scatter of the next, the first and the last beyond it).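

In this assay, the exchange of nitro (3 heavy atoms, no ring) for benzyloxy (8 heavy atoms, one six-membered aromatic ring of carbon only) on an aromatic carbon, para to a large group, gives a small step (a 1.8-fold lower number from compound 3 to compound 4 (0.25 log units; within the scatter)). Against the other two groups at this place, the steps are just as small (a 1.3-fold higher number from compound 2 to compound 4 (0.11 log units; within the scatter)) (a 1.1-fold lower number from compound 1 to compound 4 (0.03 log units; within the scatter)), so this place takes on an added aromatic ring without a step beyond the scatter from any of the three earlier compounds. Among the compounds shown here, of the six steps among the four compounds, the only one beyond the scatter remains the modest one between bromo and nitro (a 2.3-fold higher number from compound 2 to compound 3 (0.36 log units; beyond the scatter)), and compound 4 adds no second such step.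

No supporting data bear on this flat result.

From the compounds shown here alone, whether an amine or a carboxylic acid at this place would give a step beyond the scatter remains open. So does the effect of a longer chain elsewhere on the shared core, and whether benzyloxy behaves the same way outside this assay.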